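The source may hold more compounds than are shown below. What is called first, only, known or untested is meant among the compounds shown, and "the series" means these compounds.

Working notes on the series. In a functional assay on a cell-free system (Platelet, plasma, Homo sapiens) for inhibition (a lower number here means a stronger inhibitor, a higher number a weaker inhibitor), compound 1 (`O=C(NC[C@H](NS(=O)(=O)c1ccccc1)C(=O)O)c1ccc(N2CCC(NC3=NCCCN3)CC2)c(Cl)c1`) gives 90 nM. Compound 2 (`O=C(NC[C@H](NS(=O)(=O)c1ccccc1)C(=O)O)c1ccc(N2CCC[C@H](NC3=NCCCN3)C2)cc1`) gives 83 nM. For the measured compounds named here, these two values lie within the scatter of each other, so compound 1 stands level with the only other measured compound. Compound 3 (`O=C(NC[C@H](NS(=O)(=O)c1ccccc1)C(=O)O)c1ccc(N2CCC(NC3=NCCCN3)CC2)cc1`) has not yet been measured. It departs from compound 1 by hydrogen in place of chloro on an aromatic carbon, at a place on a six-membered aromatic ring of carbon only, ortho to a large group and meta to a large group. Going by the values given here, the series offers no measured step that changes one place only, so the expectation in this assay is a small shift, not clearly beyond the scatter, leaning slightly to a lower number. The expected step is a 1.3-fold lower number from compound 1 to compound 3 (0.11 log units; within the scatter). Compound 3 is estimated at 70 nM, with an expected range of 25 nM to 200 nM.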

Compound 3, half-maximal inhibitory concentration: 290 nM
For compound 3 the middle estimate is 4.1-fold (0.62 log units) below the measured one, outside the stated range (above it).
By their numbers in this assay, from the lowest: compounds 2 and 1 (each within the scatter of the next); then compound 3.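

In this assay the series now has its first reading of a change at one place only (a 3.2-fold higher number from compound 1 to compound 3 (0.51 log units; beyond the scatter)): hydrogen in place of chloro on this aromatic carbon, ortho to a large group and meta to a large group, weakens inhibition. The position is therefore not indifferent to what it carries, since a change of only 1 heavy atom, with no ring, no hydrogen-bond donors or acceptors and no net charge involved, moves the number beyond the scatter. Nothing measured here accounts for the size of this step.

As far as these compounds go, whether fluoro, bromo, methyl or methoxy at this place would match the chloro of compound 1 remains open. Also open, from the compounds shown here alone, is whether a chloro at this place would have any such effect on compound 2.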